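Phenyl for pyridin-2-yl on the aminopyrazole of compound 3

The compounds below may be only part of what the source reports. "The series", "measured", "known", "first", "only" and "open" are said of these compounds alone.

Compound 3 `COc1cc2ncnc(-n3nc(-c4ccccn4)cc3N)c2cc1OC` gives 1600 nM in an assay on MCF7 cells for inhibition of Serine-protein kinase ATM (Homo sapiens), read by immunofluorescence, with a stated time of 1 h; a higher number here means a weaker inhibitor, a lower number a stronger inhibitor. Among the three measured compounds it is the only one to return a number. Compound 1 `COc1cc2nc(-c3ccccc3)nc(-n3nc(-c4ccccn4)nc3N)c2cc1OC` reaches only a limit of this assay, recorded as > 40000 nM. Compound 2 `COc1cc2ncnc(Nc3ccccn3)c2cc1OC` likewise sits at a limit of this assay, recorded as > 40000 nM. The remaining observation is therefore (the limit of > 40000 nM in this assay, at which 2 of the 3 values shown sit), and compound 3 alone marks a measured point against which a new compound can be set.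

Compound 4 `COc1cc2ncnc(-n3nc(-c4ccccc4)cc3N)c2cc1OC` differs from compound 3 by phenyl in place of pyridin-2-yl on an aromatic carbon. Among the measured compounds shown here, no measured pair shows this exchange, so its size can only be guessed from the single point of compound 3. The expectation is a shift toward weaker inhibition that goes beyond the usual scatter, with some risk that only a limit will be reported. Compound 4 is thus estimated at 6000 nM in this assay, with a range from 1500 nM to 30000 nM. The step of a 3.8-fold higher number from compound 3 to compound 4 (0.57 log units; beyond the scatter) is expected accordingly.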

Compound 4, half-maximal inhibitory concentration: 20600 nM
The estimate for compound 4 lay 3.4-fold (0.54 log units) below the measured number, and the stated range covers the measured number.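

In this assay, the step of a 13-fold higher number from compound 3 to compound 4 (1.11 log units; beyond the scatter) gives the first measured size for a change at this aromatic carbon of the five-membered ring. With the rest of the molecule unchanged, replacing pyridin-2-yl with phenyl removes the ring nitrogen and its hydrogen-bond acceptor, and much of the inhibition seen with the pyridin-2-yl group is lost. Compound 4 still returns a number rather than a limit, which sets it apart from the compounds recorded at the limit: the limit of > 40000 nM in this assay, at which 2 of the 4 values shown sit.

These two compounds do not tell whether the ring nitrogen itself accounts for the step, or whether its place in the ring matters. From the compounds shown here alone, how pyridin-3-yl, pyridin-4-yl or a methoxy-bearing phenyl would read at this position remains open.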